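This account rests on a few compounds, and the source may have more. Where it says the series, first, only, none or still open, it means among the compounds named here.

Measured compounds:
compound 1, `C[C@H](Oc1ccc(/C=C/C(=O)O)cc1)c1c(Cl)ccc(F)c1Cl`, 2.8
compound 2, `C[C@H](Oc1cc(CO)c2ncc(/C=C/C(=O)O)c(C3CC3)c2c1)c1c(Cl)ccc(F)c1Cl`, 2.9
compound 3, `C[C@H](Oc1ccc(NC(=O)CC(N)=O)c(C2CC2)c1)c1c(Cl)ccc(F)c1Cl`, 3.9

In a physicochemical assay for lipophilicity, using the shake flask method (a higher number here means a more lipophilic compound, a lower number a more polar compound), compound 2 stands second highest of the three numbers. Its nearest neighbour is compound 1 with 2.8, a number within the scatter of compound 2 with 2.9. Compound 3 with 3.9 lies furthest away, beyond the scatter.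

Compound 4, `C[C@H](Oc1ccc2ncc(/C=C/C(=O)O)c(C3CC3)c2c1)c1c(Cl)ccc(F)c1Cl`, has not yet been measured in this assay. It differs from compound 2 in one place: hydrogen in place of hydroxymethyl on an aromatic carbon.

Within the data shown here, no step between measured compounds matches this change, so the size must be judged from the change alone. A hydroxymethyl leaving, with its donor and acceptor, is expected to raise the number beyond the scatter, as a step of a number 0.70 log units higher from compound 2 to compound 4 (beyond the scatter). Compound 4 is therefore estimated at 3.6, somewhere between 3.2 and 4.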

Compound 4, distribution coefficient: 4.1
For compound 4 the middle estimate is 0.50 log units below the measured one, and the stated range ends below it.
By their numbers in this assay, from the lowest: compounds 1 and 2 (each within the scatter of the next); then compounds 3 and 4 (each within the scatter of the next).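

Seen in this assay with the rest of the molecule unchanged, putting hydrogen in place of hydroxymethyl on this aromatic carbon gives a number 1.20 log units higher from compound 2 to compound 4 (beyond the scatter) as a large step. Among these compounds, it is the first comparison here that isolates a single place, and it shows that this one group on the shared core can move the number substantially. Nothing shown gives a reason for the size of this step.

As far as these compounds go, whether a methoxy group, an aminomethyl group or a carboxylic acid at this carbon would land nearer compound 2 or compound 4 remains open. So does whether the same change would give a step of similar size on a different core.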